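A few compounds are considered here, and "the series" means these few. Any claim that something is new, unique, unknown or untested is made for them only; others in the source may bear on it.

Measured in a functional assay on PC-12 cells (Rattus norvegicus) for cytotoxicity, read by MTT assay, with stated times of 2 h and 24 h, tested at 10 uM; on this read-out higher numbers stand for a stronger effect at the one concentration tested and lower numbers for a weaker effect:
compound 1 `CC(C)(C)c1ccc(-n2nc(-c3ccc(C(F)(F)F)cc3O)nc2-c2ccccc2O)cc1` gives 81.1%
compound 2 `Oc1cc(C(F)(F)F)ccc1-c1nc(-c2ccccc2O)n(-c2ccc(Cl)cc2)n1` gives 96.1%
compound 3 `COc1ccccc1-n1nc(-c2ccc(C(F)(F)F)cc2O)nc1-c1ccccc1O` gives 96.2%

Compound 3 stands highest of the three numbers, though its step from compound 2 is within the scatter: a number 0.1 percentage points higher from compound 2 to compound 3 (within the scatter). Against compound 1 the gap is clear: a number 15.1 percentage points higher from compound 1 to compound 3 (beyond the scatter). Compound 4 `Cc1cc(C)cc(-n2nc(-c3ccc(C(F)(F)F)cc3O)nc2-c2ccccc2O)c1` differs from compound 3 only on the aromatic nitrogen: 3,5-dimethylphenyl in place of 2-methoxyphenyl on an aromatic nitrogen. All three measured steps concern groups at this same position. Two of them, a number 15 percentage points higher from compound 1 to compound 2 (beyond the scatter) and a number 15.1 percentage points higher from compound 1 to compound 3 (beyond the scatter), are modest and beyond the scatter, while a number 0.1 percentage points higher from compound 2 to compound 3 (within the scatter) is within it; a 3,5-dimethylphenyl has not been tested there, so the direction is open. For compound 4 a step within or just beyond the scatter is expected, a number 7.2 percentage points lower from compound 3 to compound 4 (within the scatter), downward if anything, compound 3 already giving 96.2% near the top of the range seen. Compound 4 is therefore estimated at 89%, range 74% to 100%.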

Compound 4, a percentage reported as activity, at one concentration (the size of the read-out at that concentration, not a potency): 105%
Beside the measured number, compound 4's estimate is 16 percentage points below it; measured number outside the range, above it.
By their numbers in this assay, from the lowest: compound 1; then compounds 2, 3 and 4 (each within the scatter of the next).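

Swapping the oxygen-bearing 2-methoxyphenyl or the 4-chlorophenyl for the all-carbon 3,5-dimethylphenyl gives a number 8.8 percentage points higher from compound 3 to compound 4 (within the scatter) and a number 8.9 percentage points higher from compound 2 to compound 4 (within the scatter), so these three groups on the aromatic nitrogen cannot be told apart, and the hydrogen-bond acceptor of 2-methoxyphenyl is not needed to stay in this group. Only 4-(tert-butyl)phenyl stands apart, now by a wider margin: a number 23.9 percentage points higher from compound 1 to compound 4 (beyond the scatter). Nothing at hand accounts for these numbers.

Open, as far as these compounds go, is whether an amine or a carboxylic acid on this phenyl keeps the number in the same range. Also open, from the compounds shown here alone, is how a longer alkyl chain in place of the phenyl on the aromatic nitrogen would read.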